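Oxazole ketones against diacylglycerol lipase-alpha: bromo for trifluoromethyl

This account rests on a few compounds, and the source may have more. Where it says the series, first, only, none or still open, it means among the compounds named here.

Within the data shown here, two ketones have numbers so far. Compound 1 `O=C(CCCCCc1ccccc1)c1nc2cc([N+](=O)[O-])ccc2o1` carries a nitro group on its fused core; in an assay on HEK-293T cells for inhibition of diacylglycerol lipase-alpha (Homo sapiens), read by colorimetric assay (a higher number here means a weaker inhibitor, a lower number a stronger inhibitor), compound 1 gives 891 nM. Compound 2 `O=C(CCCCCCc1ccccc1)c1nc(C(F)(F)F)co1` has a chain one carbon longer and a trifluoromethyl on a five-membered core; in this assay compound 2 gives 214 nM. Compound 2 thus stands at the lower of the two numbers, and the gap to compound 1 lies beyond the usual scatter. The two compounds differ in several places at once, so no single step can be read from them.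

Compound 3 `O=C(CCCCCCc1ccccc1)c1nc(Br)co1` keeps the chain and core of compound 2 and changes one group: bromo in place of trifluoromethyl on an aromatic carbon. Among the measured compounds shown here, no measured pair shows this exchange, so the expected step from compound 2 to compound 3 is set small, a 1.4-fold higher number from compound 2 to compound 3 (0.15 log units; within the scatter), with its direction uncertain. In this assay compound 3 is therefore estimated at 300 nM, with a range from 110 nM to 850 nM.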

Compound 3, half-maximal inhibitory concentration: > 10000 nM
Compound 3: only a limit was reported; the forecaster's own chance of this, stated with the estimate: 5%; middle value at least 33-fold (1.52 log units) from the limit.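

The aromatic carbon next to the ring nitrogen proves highly sensitive: with chain and core unchanged, bromo in place of trifluoromethyl costs a large loss in this assay (an at least 46-fold higher number from compound 2 to compound 3 (1.66 log units; beyond the scatter)). The activity of compound 2 therefore depends on the group at this carbon, not on its chain and core alone. For compound 3, the reported > 10000 nM is a limit of the assay and not a number, so the step is a bound and its full size remains unknown: the limit of > 10000 nM in this assay, at which 1 of the 3 values shown sits.

On these data alone, whether a nitrile, a methyl or an ester at this carbon would retain the level of compound 2 remains open, so what trifluoromethyl contributes here cannot be told from these compounds. Also open, as far as these compounds go, is whether a shorter chain would change the size of this step.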